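Swapping the amide aryl group: cytotoxicity expected unchanged

A few compounds are considered here, and "the series" means these few. Any claim that something is new, unique, unknown or untested is made for them only; others in the source may bear on it.

Compound 3 `Cc1cnc(NC(=O)CSc2nncnc2-c2ccccc2Cl)c(Br)c1` was tested in an ADME assay on MT4 cells (Homo sapiens) for cytotoxicity, read by MTT assay (on this read-out lower numbers stand for higher toxicity in this test and higher numbers for lower toxicity in this test), where compound 3 gives 144000 nM. Within the data shown here, its number is the highest of the three measured so far. Compound 2 `O=C(CSc1nncnc1-c1ccccc1Cl)Nc1ccccc1` gives 127000 nM in this assay, a gap that lies within the scatter, while compound 1 `O=C(CSc1nncnc1-c1ccccc1Cl)c1ccc(Cl)c(Cl)c1` gives 33000 nM, a gap beyond it. Compound 4 `O=C(CSc1nncnc1-c1ccccc1Cl)Nc1ccccc1F` differs from compound 3 in one place: 2-fluorophenyl in place of 3-bromo-5-methylpyridin-2-yl on an amide-type nitrogen. The closest guide is the earlier exchange on the same amide-type nitrogen, a 1.1-fold higher number from compound 2 to compound 3 (0.05 log units; within the scatter). The other step, a 3.8-fold higher number from compound 1 to compound 2 (0.59 log units; beyond the scatter), altered the carbonyl carbon instead and bears less on this change. A step no larger than the scatter is therefore expected, a 1.1-fold lower number from compound 3 to compound 4 (0.04 log units; within the scatter). Compound 4 is estimated at 130000 nM, within 60000 nM to 280000 nM.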

Compound 4, half-maximal cytotoxic concentration: 98000 nM
Compound 4: the middle estimate sits 1.3-fold (0.12 log units) above what was measured, and the stated range covers the measured number.
By their numbers in this assay, from the lowest: compound 1; then compounds 4, 2 and 3 (each within the scatter of the next).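

In this assay, the amide-type nitrogen has now carried three different aromatic groups without a step beyond the scatter: a 1.5-fold lower number from compound 3 to compound 4 (0.17 log units; within the scatter) exchanges 3-bromo-5-methylpyridin-2-yl for 2-fluorophenyl, and a 1.3-fold lower number from compound 2 to compound 4 (0.11 log units; within the scatter) adds fluoro to the aromatic carbon. Among these compounds, the only larger change remains at the carbonyl carbon, where a 3.0-fold higher number from compound 1 to compound 4 (0.47 log units; beyond the scatter) shows that (2-fluorophenyl)amino, like anilino, differs clearly from 3,4-dichlorophenyl. As far as these compounds go, whether a non-aromatic group such as cyclohexyl, or a carboxylic acid on the ring, would move the number beyond the scatter on this nitrogen stays open. No measurement shown here explains these results.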